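A few compounds are considered here, and "the series" means these few. Any claim that something is new, unique, unknown or untested is made for them only; others in the source may bear on it.

Measured so far in an assay on isolated protein for inhibition of STE20-like serine/threonine-protein kinase (Homo sapiens), read by thermal shift assay, tested at 10 uM; a higher number here means that the compound stabilises the target more against heat, a lower number that the compound stabilises the target less:
Compound 1 `CC(C)(C)c1cc(NC(=O)Nc2cc(C(F)(F)F)cc(C(F)(F)F)c2)n(-c2ccccc2)n1` gives 0 degrees C.
Compound 2 `CC(C)(C)c1cc(NC(=O)Nc2cc(C(F)(F)F)cc(C(F)(F)F)c2)n(C(C)(C)C)n1` gives -0.2 degrees C.

Going by the values given here, compound 2 holds the lower of these two numbers, but the only measured step, a number 0.20 degrees C lower from compound 1 to compound 2 (within the scatter), lies within the scatter of this kind of measurement, so the two compounds cannot be told apart on what has been measured. Neither shows a clear stabilising effect on the protein.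

Compound 3 `CC(C)(C)c1cc(NC(=O)Nc2cc(C(F)(F)F)cc(C(F)(F)F)c2)n(-c2ccc(Br)cc2)n1` differs from compound 2 in one place: 4-bromophenyl in place of tert-butyl on an aromatic nitrogen. Among the compounds with values here, the one measured step bears directly on this change, since it exchanged the same two kinds of group at the same aromatic nitrogen, only in the opposite direction, and it moved the number by a number 0.20 degrees C lower from compound 1 to compound 2 (within the scatter), which is within the scatter. Within the data shown here, compound 3 reverses that exchange and adds a bromine to the phenyl; no measured pair shows what that bromine does on its own. The expectation for the step is therefore no change beyond the scatter, a number 0.30 degrees C higher from compound 2 to compound 3 (within the scatter). Compound 3 is expected at 0.1 degrees C, with a range from -1 degrees C to 1.2 degrees C.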

Compound 3, shift of the target's melting temperature: 0.1 degrees C
The estimate for compound 3 equals the measured number at the digits printed; the range from low to high includes it.
By their numbers in this assay, from the lowest: compounds 2, 1 and 3 (each within the scatter of the next).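

The bromine on the phenyl ring can now be read on its own: in this assay, bromo in place of hydrogen on an aromatic carbon gives a number 0.10 degrees C higher from compound 1 to compound 3 (within the scatter) and so leaves the thermal stabilisation indistinguishable from that of the unsubstituted phenyl compound. The exchange at the aromatic nitrogen can also now be read with a substituted ring, and 4-bromophenyl in place of tert-butyl gives a number 0.30 degrees C higher from compound 2 to compound 3 (within the scatter) in the same measurement, so these two groups cannot be told apart at this position either. No separate measurement is available to help interpret these results.

Across tert-butyl, phenyl and 4-bromophenyl on this nitrogen, the three compounds stay within the scatter of one another, so the position has yet to show any difference that can be read in this assay. From the compounds shown here alone, it remains open whether a ring carrying an amine or a carboxylic acid, or a longer chain on this nitrogen, would give a clear stabilisation, and what a change elsewhere on the shared core would do.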